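The source may report more compounds than this note shows. Statements on the series, on what has been measured and on what is new or still open speak of the compounds shown alone.

Working notes on the series. Compound 1 `CCOC(=O)CSc1nncc2c(C)nc(C)n12` carries the core with two methyl groups and an ethyl ester side chain. In a functional assay for inhibition, with Homo sapiens as the target (on this read-out lower numbers stand for stronger inhibition and higher numbers for weaker inhibition), compound 1 reaches only the limit of the assay, > 48000 nM, which is a limit and not a number; this is the limit of > 48000 nM in this assay, at which 1 of the 2 values shown sits. Compound 2 `C=CCSc1nncc2cnc(C)n12` carries the allyl sulfide on a core with a single methyl group. In this assay, among the compounds with values here, compound 2 gives 61000 nM, the only full number in the set so far.

Compound 3 `C=CCSc1nncc2c(C)nc(C)n12` keeps the allyl sulfide of compound 2 and takes up the second methyl group of compound 1. The change from compound 2 to compound 3 is methyl in place of hydrogen on an aromatic carbon. Within the data shown here, no step between two measured compounds is available to size this change. The expectation is a step of a 1.0-fold lower number from compound 2 to compound 3 (0.01 log units; within the scatter) that stays within the scatter, with no direction claimed. Compound 3 is therefore estimated at 60000 nM, expected between 25000 nM and 150000 nM.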

Compound 3, half-maximal inhibitory concentration: 59000 nM
Compound 3: middle estimate off by 1.0-fold (0.01 log units), on the high side, within the range that was stated.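

In this assay, within the data shown here, methyl in place of hydrogen on an aromatic carbon gives a 1.0-fold lower number from compound 2 to compound 3 (0.01 log units; within the scatter), the first sized step at this position of the shared core. With the allyl sulfide held constant, the added methyl group shows no difference beyond the scatter in this one pair. The step between compound 1 and compound 3 cannot be read, because compound 1 stands at a limit and not a number: the limit of > 48000 nM in this assay, at which 1 of the 3 values shown sits.

Going by these compounds, whether an ethyl group, a chlorine atom or an amine at this position would give a step beyond the scatter remains open. Also open, on these data alone, is how a carboxylic acid or a longer chain on the sulfur would compare with the allyl sulfide on the core of compound 3.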